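The compounds below may be only part of what the source reports. "The series", "measured", "known", "first", "only" and "open" are said of these compounds alone.

Working notes on the series. In an assay on HEK293 cells for inhibition of Voltage-dependent N-type calcium channel subunit alpha-1B (Homo sapiens), read by FLIPR and calcium flux, tested at 1 uM (a higher number here means more inhibition at the concentration tested (going by the name of the read-out), a lower number less inhibition), compound 1 `CS(=O)(=O)c1ccc(C(=O)N2CCC(N(C3CC3)S(=O)(=O)c3cccc(C(F)(F)F)c3)CC2)cc1` gives 52%, the highest of the two numbers recorded; the nearest, compound 2 `CS(=O)(=O)c1ccc(F)cc1C(=O)N1CCC(N(C2CC2)S(=O)(=O)c2ccc(OC(F)(F)F)cc2)CC1`, gives 0%, a gap beyond the scatter. Compound 3 `NC(=O)c1cccc(C(=O)N2CCC(N(C3CC3)S(=O)(=O)c3cccc(C(F)(F)F)c3)CC2)c1` is not yet measured. It differs from compound 1 at one place: 3-carbamoylphenyl in place of 4-(methylsulfonyl)phenyl on a carbonyl carbon. Among the compounds with values here, no pair of measured compounds differing in one place is available, so the step has no precedent here. A modest drop, or none beyond the scatter, is expected: the step from compound 1 to compound 3 is estimated at a number 12 percentage points lower from compound 1 to compound 3 (beyond the scatter). Compound 3 is expected to give 40%, within 10% to 70%.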

Compound 3, a percentage reported as inhibition, at one concentration (the size of the read-out at that concentration, not a potency): 0%
Compound 3: middle estimate off by 40 percentage points, on the high side, outside the stated range (below it).
By their numbers in this assay, from the lowest: compounds 2 and 3 (each within the scatter of the next); then compound 1.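

Within the data shown here, this is the first step that changes one place only: 3-carbamoylphenyl in place of 4-(methylsulfonyl)phenyl on a carbonyl carbon gives a number 52 percentage points lower from compound 1 to compound 3 (beyond the scatter) in this assay. The inhibition seen with the core of compound 1 therefore depends strongly on the group at this position and does not survive this exchange. No measurement shown bears on what lies behind the loss. From the compounds shown here alone, whether a plain phenyl or a sulfonamide at this position would retain any of the inhibition of compound 1 remains open.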